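The source may report more compounds than this note shows. Statements on the series, on what has been measured and on what is new or still open speak of the compounds shown alone.

Within the data shown here, compound 1 `O=C(Cn1ccnc1)N1CCC(NS(=O)(=O)c2cc(S(=O)(=O)c3ccccc3)ccc2C(F)(F)F)CC1` gives 30 nM in an assay on isolated protein for binding affinity to secreted frizzled-related protein 1 (Homo sapiens), read by fluorescence (a higher number here means a weaker inhibitor, a lower number a stronger inhibitor), and stands lowest of the three numbers measured so far. Compound 3 `O=C([C@@H]1CCCN1C(=O)c1ccncc1)N1CCC(NS(=O)(=O)c2cc(S(=O)(=O)c3ccccc3)ccc2C(F)(F)F)CC1` gives 70 nM in this assay, and compound 2 `CN(C)c1ccc(C(=O)N2CCC[C@H]2C(=O)N2CCC(NS(=O)(=O)c3cc(S(=O)(=O)c4ccccc4)ccc3C(F)(F)F)CC2)cc1` gives 110 nM in this assay, both beyond the scatter from compound 1. The step of a 1.6-fold lower number from compound 2 to compound 3 (0.20 log units; within the scatter) lies within the scatter. Compound 4 `CCNC(=O)N1CCC[C@H]1C(=O)N1CCC(NS(=O)(=O)c2cc(S(=O)(=O)c3ccccc3)ccc2C(F)(F)F)CC1` is not yet measured; its change from compound 1 is 1-(ethylcarbamoyl)pyrrolidin-2-yl in place of (1H-imidazol-1-yl)methyl on a carbonyl carbon. Among the measured compounds shown here, no measured step matches this change directly. Compounds 2 and 3 also carry a pyrrolidin-2-yl on a carbonyl carbon and both sit higher than compound 1. A modest rise is therefore expected for compound 4, estimated as a 2.2-fold higher number from compound 1 to compound 4 (0.34 log units; beyond the scatter). Compound 4 is expected to give 65 nM, within 25 nM to 180 nM.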

Compound 4, half-maximal inhibitory concentration: 30 nM
Compound 4: middle estimate off by 2.2-fold (0.34 log units), on the high side; the range from low to high includes it.
By their numbers in this assay, from the lowest: compounds 1 and 4 (each within the scatter of the next); then compounds 3 and 2 (each within the scatter of the next).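

The pyrrolidin-2-yl on the carbonyl carbon does not by itself raise the number in this assay: the step shows no change at the digits printed from compound 1 to compound 4 (within the scatter). What that ring carries on its own carbonyl carbon does count, with ethylamino giving a 2.3-fold lower number from compound 3 to compound 4 (0.37 log units; beyond the scatter) and a 3.7-fold lower number from compound 2 to compound 4 (0.56 log units; beyond the scatter), whereas the earlier exchange of aryl groups stayed within the scatter. No measurement on hand accounts for these steps. Open, on these data alone, is whether a longer chain or a cyclic amine in place of ethylamino holds this level. As far as these compounds go, the other configuration at the defined stereocentre also remains open.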